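The compounds below may be only part of what the source reports. "The series", "measured", "known", "first", "only" and "open" are said of these compounds alone.

Among the compounds with values here, in a functional assay on CCRF-CEM cells (Homo sapiens) for inhibition, read by MTT assay, with a stated time of 72 h (on this read-out lower numbers stand for stronger inhibition and higher numbers for weaker inhibition), two compounds have numbers so far. Compound 1 `C=C(Br)C(=O)Nc1cccc(/C=C/C(=O)Nc2cccc3ccccc23)c1` gives 1800 nM as its result. Compound 2 `C=C(Br)C(=O)Nc1cccc(/C=C/C(=O)Nc2ccc(F)cc2)c1` gives 16600 nM in the same test, the higher of the two numbers and so the weaker result, and its gap to compound 1 lies beyond the scatter. Compound 3 `C=C(Br)C(=O)Nc1cccc(/C=C/C(=O)Nc2ccc(C)cc2)c1` has not yet been measured. It differs from compound 2 in one place, where 4-fluorophenyl becomes 4-methylphenyl, with methyl in place of fluoro on an aromatic carbon, para to a large group: methyl in place of fluoro on an aromatic carbon is the whole change. Within the data shown here, no measured pair shows this exchange, so the expectation stays close to compound 2 at 16600 nM as its starting point. The expected 1.4-fold lower number from compound 2 to compound 3 (0.14 log units; within the scatter) is small, leaning to a slightly lower number but not beyond the scatter. Compound 3 is estimated at 12000 nM within a range from 5000 nM to 28000 nM for now.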

Compound 3, half-maximal inhibitory concentration: 270 nM
Estimate against measurement, compound 3: 44-fold (1.65 log units) above; measured number below the stated range.
By their numbers in this assay, from the lowest: compound 3; then compound 1; then compound 2.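

In this assay, methyl in place of fluoro on an aromatic carbon, para to a large group, gives a 61-fold lower number from compound 2 to compound 3 (1.79 log units; beyond the scatter), a large step for the exchange of one heavy atom for one other. This position is therefore far from indifferent to what it carries, even though the two groups match in heavy-atom count, with no ring, no hydrogen-bond donors or acceptors and no net charge on either. The data shown offer nothing that would explain the size of this step.

The compounds shown leave open whether the lower number is particular to methyl or would also appear with chloro, methoxy or a longer chain such as ethyl on the same carbon. From the compounds shown here alone, whether the same exchange gives a step of similar size elsewhere also remains open.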